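The source may hold more compounds than are shown below. What is called first, only, known or untested is meant among the compounds shown, and "the series" means these compounds.

Of the compounds shown here, three have been measured in an ADME assay on microsomes from liver (Homo sapiens) for metabolic stability; on this read-out lower numbers stand for a shorter-lived compound and higher numbers for a longer-lived compound. Compound 1 `CNC(=O)c1cc(-n2ncc3cc(Nc4ccccc4Cl)c(F)cc32)cs1` gives 0.617 h, compound 2 `O=C(NC1COC1)c1cc(-n2ncc3cc(Nc4ccccc4Cl)c(F)cc32)cs1` gives 1.53 h, and compound 3 `O=C(NC1COC1)c1cc(-n2ncc3cc(Nc4ccccc4Cl)cnc32)cs1` gives 0.35 h; the gap between compound 3 and compound 1 stays within the scatter, while compound 3 sits beyond the scatter below compound 2. Compound 4 `CNC(=O)c1cc(-n2ncc3cc(Nc4ccccc4Cl)cnc32)cs1` differs from compound 3 by one change: methyl in place of oxetan-3-yl on an amide-type nitrogen. A single measured step bears on this exchange, run in the opposite direction: a 2.5-fold higher number from compound 1 to compound 2 (0.39 log units; beyond the scatter). Reversing that step, compound 4 is expected to show a 2.5-fold lower number from compound 3 to compound 4 (0.40 log units; beyond the scatter) in this assay, a downward move of similar size. The estimate for compound 4 is therefore 0.14 h, with a range from 0.07 h to 0.32 h.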

Compound 4, half-life: 0.25 h
Beside the measured number, compound 4's estimate is 1.8-fold (0.25 log units) below it; measured number inside the range.
By their numbers in this assay, from the lowest: compounds 4, 3 and 1 (each within the scatter of the next, the first and the last beyond it); then compound 2.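

Swapping oxetan-3-yl for methyl on the amide-type nitrogen of the core of compound 3 gives a 1.4-fold lower number from compound 3 to compound 4 (0.15 log units; within the scatter) in this assay, so on this core the change cannot be told apart from repeat scatter. The clear step seen on the core of compound 1 is therefore not shown to carry over, yet the two results do not firmly disagree: the same change on two cores in this assay, a 2.5-fold higher number (0.39 log units; beyond the scatter) from compound 1 to compound 2 and a 1.4-fold higher number (0.15 log units; within the scatter) from compound 4 to compound 3, 1.8-fold (0.25 log units) apart, within the scatter of two such steps.

Only methyl and oxetan-3-yl appear at this position. Going by these compounds, how cyclobutyl, the same-sized ring without oxygen, or a longer chain such as propyl would behave on either core stays open.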